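The compounds below may be only part of what the source reports. "The series", "measured", "known", "first", "only" and "open" are said of these compounds alone.

Of the compounds shown here, three have been measured in an in vitro assay on CHOK cells for displacement of a labelled ligand from growth hormone secretagogue receptor type 1 (Homo sapiens); on this read-out lower numbers stand for stronger inhibition and higher numbers for weaker inhibition. Compound 1, `CCc1nc(N)nc(N)c1-c1ccc(NCc2ccc(S(C)(=O)=O)cc2)cc1`, gives 7.4 nM in this assay. Compound 2, `CCc1nc(N)nc(N)c1-c1ccc(NCc2cc(F)c(S(=O)(=O)C(F)(F)F)c(F)c2)cc1`, gives 21 nM in this assay. Compound 3, `Nc1nc(N)c(-c2ccc(NCc3ccc([N+](=O)[O-])cc3)cc2)c(COCc2ccccc2)n1`, gives 0.2 nM in this assay, the lowest of the three numbers and the strongest binding in the set; its gaps to compound 1 and to compound 2 both lie beyond the usual scatter of such measurements. Compound 3 differs from the other two in its core as well as in the group on the benzyl arm, so no single change accounts for its standing.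

Compound 4, `Nc1nc(N)c(-c2ccc(NCc3ccncc3)cc2)c(COCc2ccccc2)n1`, has not yet been measured. It keeps the core and the linker of compound 3 and changes one part: pyridin-4-yl in place of 4-nitrophenyl on a saturated chain carbon bound to a nitrogen on an aromatic ring. Among the compounds with values here, nothing among the measured compounds isolates this exchange, so the size of the step has to be guessed. The expectation is that the step from compound 3 to compound 4 amounts to a 10-fold higher number from compound 3 to compound 4 (1.00 log units; beyond the scatter), a loss of binding that goes beyond the scatter, since the nitro-bearing arm of compound 3 sits at the strong end of the set with its 0.2 nM and a smaller, nitrogen-containing ring replaces it. On that basis compound 4 is estimated to give 2 nM in this assay, within a range from 0.4 nM to 15 nM.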

Compound 4, half-maximal inhibitory concentration: 21 nM
For compound 4 the middle estimate is 11-fold (1.02 log units) below the measured one, outside the stated range (above it).
By their numbers in this assay, from the lowest: compound 3; then compound 1; then compounds 2 and 4 (each within the scatter of the next).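

Within the data shown here, with the core and the linker held fixed, replacing 4-nitrophenyl with pyridin-4-yl on a saturated chain carbon bound to a nitrogen on an aromatic ring gives, in this assay, a 110-fold higher number from compound 3 to compound 4 (2.02 log units; beyond the scatter) in the only comparison here where just one place differs. Among these compounds, this shows that the group at this position has a large effect on the read-out, which the earlier compounds could not show, since they differ from each other in more than one place. Nothing shown here bears on why the step is so large.

The exchange also makes several changes at once: the nitro group leaves, a ring nitrogen enters, and the group goes from 9 heavy atoms to 6, so this single step cannot say which of these changes matters. A plain phenyl ring or a 4-cyanophenyl group at the same position could help to separate them, and the same exchange on the core of compound 1 would test whether a step of this size holds on another core.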